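Swapping Methoxy for Trifluoromethyl on the Pendant Phenyl

A few compounds are considered here, and "the series" means these few. Any claim that something is new, unique, unknown or untested is made for them only; others in the source may bear on it.

Of the compounds shown here, three sharing one core have been measured in a functional assay on A549 cells (Homo sapiens) for cytotoxicity, read by MTT assay, with a stated time of 72 h; on this read-out higher numbers stand for weaker inhibition and lower numbers for stronger inhibition. Compound 1 `O=C(Nc1ccc(Oc2ccnc3[nH]ccc23)c(F)c1)c1cc(-c2ccccc2)ccn1` gives 4950 nM, compound 2 `Cc1ccc(-c2ccnc(C(=O)Nc3ccc(Oc4ccnc5[nH]ccc45)c(F)c3)c2)cc1` gives 3120 nM, and compound 3 `COc1ccc(-c2ccnc(C(=O)Nc3ccc(Oc4ccnc5[nH]ccc45)c(F)c3)c2)cc1` gives 1040 nM. Compound 3 stands lowest of the three: the steps of a 4.8-fold lower number from compound 1 to compound 3 (0.68 log units; beyond the scatter) and a 3.0-fold lower number from compound 2 to compound 3 (0.48 log units; beyond the scatter) both lie beyond the scatter, while a 1.6-fold lower number from compound 1 to compound 2 (0.20 log units; within the scatter) does not. Compound 4 `O=C(Nc1ccc(Oc2ccnc3[nH]ccc23)c(F)c1)c1cc(-c2ccc(C(F)(F)F)cc2)ccn1` differs from compound 3 by trifluoromethyl in place of methoxy on an aromatic carbon. No measured step pairs trifluoromethyl with any other group at this carbon, so the steps that bear on the change are indirect: the methoxy group that leaves accounts for the gains seen in a 4.8-fold lower number from compound 1 to compound 3 (0.68 log units; beyond the scatter) and a 3.0-fold lower number from compound 2 to compound 3 (0.48 log units; beyond the scatter), and nothing shown tells whether trifluoromethyl recovers them. Hydrogen and methyl at this carbon both gave higher numbers than methoxy. Compound 4 is therefore expected to give a higher number than compound 3, a step of a 2.9-fold higher number from compound 3 to compound 4 (0.46 log units; beyond the scatter), with wide uncertainty. The estimate for compound 4 is 3000 nM, within a range from 1000 nM to 9000 nM.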

Compound 4, half-maximal inhibitory concentration: 4920 nM
Beside the measured number, compound 4's estimate is 1.6-fold (0.21 log units) below it; low and high end bracket the measured number.
By their numbers in this assay, from the lowest: compound 3; then compounds 2, 4 and 1 (each within the scatter of the next).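

In this assay trifluoromethyl gives up all that methoxy had gained at this carbon (a 4.7-fold higher number from compound 3 to compound 4 (0.67 log units; beyond the scatter)), so among the four groups shown, only methoxy gives the lower number. Trifluoromethyl cannot be told apart from methyl (a 1.6-fold higher number from compound 2 to compound 4 (0.20 log units; within the scatter)) or from hydrogen (a 1.0-fold lower number from compound 1 to compound 4 (0.00 log units; within the scatter)), as both steps lie within the scatter, which leaves compound 3 alone against the other three. Nothing at hand explains why methoxy stands apart at this carbon.

The compounds shown leave open whether a hydroxyl, an ethoxy group or an amine at this carbon would share the lower number of methoxy or fall with the other three groups. They also leave open whether the step from methoxy to trifluoromethyl would keep its size on a core other than the shared one.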